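A few compounds are considered here, and "the series" means these few. Any claim that something is new, unique, unknown or untested is made for them only; others in the source may bear on it.

Working notes on the series. Compound 1 (`CCN1CCc2c(sc(NC(=O)Nc3ccccc3)c2C(N)=O)C1`) reads > 25000 nM in a functional assay (strain AB) with Danio rerio as the target, read by microscopy, with a stated time of 1 h (a higher number here means that more compound is needed for the effect, a lower number that less compound is needed), and this is a limit of the assay, not a number. Its place among the values shown is therefore open-ended (the limit of > 25000 nM in this assay, at which 1 of the 3 values shown sits).

Compound 2 (`CN1CCc2c(sc(NC(=O)Nc3ccc(Cl)cc3)c2C(N)=O)C1`) gives 4700 nM in this assay, and compound 3 (`CC(C)(C)C[N+]1(C)CCc2c(sc(NC(=O)Nc3ccc(Cl)cc3)c2C(N)=O)C1`) gives 290 nM. For the measured compounds named here, neither differs from compound 1 in one place only, and no measured pair differs in one place, so these two values offer only a rough sense of the range that this assay covers.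

Compound 4 (`CCN1CCc2c(sc(NC(=O)Nc3cccc(C#N)c3)c2C(N)=O)C1`) is not yet measured. It keeps the core of compound 1 and changes phenyl to 3-cyanophenyl, with cyano in place of hydrogen on an aromatic carbon, meta to a large group (cyano in place of hydrogen on an aromatic carbon).

Going by the values given here, no measured step shows what this change does in this assay. A modest shift towards less compound needed is expected, though another result reported only as a limit remains quite possible. The starting point for this expectation is compound 1 at > 25000 nM, which is only a limit. The estimated change is an at least 1.6-fold lower number from compound 1 to compound 4 (0.22 log units; that floor lies within the scatter). For compound 4 the expected value is 15000 nM, with an estimated range of 4000 nM to 40000 nM.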

Compound 4, half-maximal effective concentration: 10300 nM
The estimate for compound 4 lay 1.5-fold (0.16 log units) above the measured number; measured number inside the range.
By their numbers in this assay, from the lowest: compound 3; then compound 2; then compound 4. At a limit, above all of these: compound 1.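

In this assay, for the compounds shown here, the only step that can be read puts cyano in place of hydrogen on an aromatic carbon, meta to a large group, and it gives an at least 2.4-fold lower number from compound 1 to compound 4 (0.38 log units; beyond the scatter). Going by these compounds alone, this shows what the earlier compounds could not: on the core of compound 1, with its ethyl-bearing ring nitrogen kept, this single change on the phenyl ring is enough to turn a read-out without a number into a measured value, and the step lies beyond the scatter even at its floor. The true size of the step stays unknown because compound 1 is a limit of the assay, not a number: the limit of > 25000 nM in this assay, at which 1 of the 4 values shown sits.

The compounds shown leave open whether a methoxy group, an amine or a carboxylic acid at this same place would give a step of similar size, and whether cyano would do the same elsewhere on the ring. They also leave open how this change acts alongside the other differences seen in compound 2 and compound 3, which differ from compound 4 in more than one place and so offer no comparison.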